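Variation of the acyl group on the aryl ketone

A few compounds are considered here, and "the series" means these few. Any claim that something is new, unique, unknown or untested is made for them only; others in the source may bear on it.

Compound 3 `C=C(C)C(=O)c1ccc(OCCCN2CCN(C(=O)OCC)CC2)cc1` stands second highest of the three values in an assay on isolated protein for binding affinity to histamine H2 receptor (Homo sapiens) (on this read-out lower numbers stand for stronger inhibition and higher numbers for weaker inhibition), giving 22400 nM. Compound 2 `CCOC(=O)N1CCN(CCCOc2ccc(C(=O)CC(C)C)cc2)CC1` is the nearest of the measured compounds and gives 69200 nM. Compound 1 `CCCCCCCCC(=O)c1ccc(OCCCN2CCN(C(=O)OCC)CC2)cc1` is the furthest and gives 2690 nM. Compound 4 `CCOC(=O)N1CCN(CCCOc2ccc(C(=O)c3ccc(F)cc3)cc2)CC1` is not yet measured; its change from compound 3 is 4-fluorophenyl in place of 1-methylethenyl on a carbonyl carbon.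

The measured steps that bear on this change all alter the group on the carbonyl carbon. The step of an 8.3-fold higher number from compound 1 to compound 3 (0.92 log units; beyond the scatter) and the step of a 3.1-fold lower number from compound 2 to compound 3 (0.49 log units; beyond the scatter) show that, among these three compounds, the octyl of compound 1 gives the lowest number and the isobutyl of compound 2 the highest; the step of a 26-fold higher number from compound 1 to compound 2 (1.41 log units; beyond the scatter) points the same way. Going by the values given here, the 4-fluorophenyl entering in compound 4 carries more heavy atoms than the leaving 1-methylethenyl, but none of the measured steps introduces an aromatic ring, so the carry-over is uncertain.

The expected step is a 4.5-fold lower number from compound 3 to compound 4 (0.65 log units; beyond the scatter), modest and downward. Compound 4 is therefore estimated at 5000 nM in this assay, with a range from 1000 nM to 25000 nM.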

Compound 4, inhibition constant: 42700 nM
Compound 4: the middle estimate sits 8.5-fold (0.93 log units) below what was measured; the whole stated range lies below it.
By their numbers in this assay, from the lowest: compound 1; then compounds 3, 4 and 2 (each within the scatter of the next, the first and the last beyond it).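

In this assay, the 4-fluorophenyl on this carbonyl carbon brings an aromatic ring and 7 heavy atoms, yet the exchange for 1-methylethenyl gives a 1.9-fold higher number from compound 3 to compound 4 (0.28 log units; within the scatter), and the exchange for isobutyl gives a 1.6-fold lower number from compound 2 to compound 4 (0.21 log units; within the scatter), both within the scatter. The octyl group remains clearly apart, with a 16-fold higher number from compound 1 to compound 4 (1.20 log units; beyond the scatter), so across these four compounds a larger group does not by itself go with a lower number: compound 4 goes against such a pattern, while compound 1 is the only one that reaches the low end of the series. No supporting data are available to explain this result.

Still open, as far as these compounds go, is whether the low number of compound 1 follows chain length alone, which a hexyl chain or a chain longer than octyl on the same carbonyl carbon would test. Also open, from the compounds shown here alone, is how an unsubstituted phenyl, a benzyl group, or a chain ending in an amine or a carboxylic acid would read in this assay at this position.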